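Swapping the Aryl Group on a Ring Nitrogen

The source may hold more compounds than are shown below. What is called first, only, known or untested is meant among the compounds shown, and "the series" means these compounds.

The series shares one core, seen in compound 1 `CC(C)n1ncc2c(C(=O)Nc3ccccc3)cccc21`, which carries a phenyl amide. In a functional assay on MCF7 cells (Homo sapiens) for inhibition, read by MTT assay, with a stated time of 72 h (on this read-out higher numbers stand for weaker inhibition and lower numbers for stronger inhibition), compound 1 gives 19700 nM. Compound 2 `CC(C)n1ncc2c(C(=O)NC3CCCC3)cccc21` replaces that phenyl with cyclopentyl. In this assay compound 2 reaches only the limit of > 40000 nM. The step of an at least 2.0-fold higher number from compound 1 to compound 2 (0.30 log units; that floor lies within the scatter) is therefore known only as a floor. Compound 3 `Cc1ccc(-n2cc(CNC(=O)c3cccc4c3cnn4C(C)C)nn2)cc1C` carries a 3,4-dimethylphenyl on the five-membered aromatic ring with 3 nitrogen. In this assay compound 3 likewise stops at the limit of > 40000 nM. Compound 3 thus stands at the limit of > 40000 nM in this assay, at which 2 of the 3 values shown sit, with no number of its own to set against compound 1.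

Compound 4 `CC(C)n1ncc2c(C(=O)NCc3cn(-c4ccc(I)cc4)nn3)cccc21` differs from compound 3 by one change: 4-iodophenyl in place of 3,4-dimethylphenyl on an aromatic nitrogen. Going by the values given here, no measured step covers a change on this ring nitrogen; the single step of an at least 2.0-fold higher number from compound 1 to compound 2 (0.30 log units; that floor lies within the scatter) concerns the amide nitrogen and itself sits within the scatter. The exchange keeps one six-membered aromatic ring of carbon only in the same place, so no movement beyond the scatter is expected, and compound 4 is expected to remain at the limit as well. The step that the limit leaves unreadable from compound 3 to compound 4 is estimated to be essentially flat. Compound 4 is therefore estimated at 45000 nM, within 15000 nM to 120000 nM.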

Compound 4, half-maximal inhibitory concentration: > 40000 nM
Compound 4 gave a limit, no number; the forecaster's own chance of this, stated with the estimate: 75%; the middle value does not contradict the limit.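

Compound 3 and compound 4 both return only a limit in this assay, so the exchange of 3,4-dimethylphenyl for 4-iodophenyl yields no readable step between them: the limit of > 40000 nM in this assay, at which 3 of the 4 values shown sit.

The compounds shown leave open how compound 3 and compound 4 truly compare, and whether the aryl group on the ring nitrogen affects inhibition in this assay at all.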